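The source may report more compounds than this note shows. Statements on the series, on what has been measured and on what is new or still open speak of the compounds shown alone.

Measured in an ADME assay on HEK293 cells (Homo sapiens) for cytotoxicity, read by MTT assay, with a stated time of 24 h; a higher number here means a weaker inhibitor, a lower number a stronger inhibitor:
- compound 1 `O=[N+]([O-])c1ccc2nc(NCc3ccc(C(F)(F)F)cc3)c(N3CCCCC3)nc2c1` gives > 200 ug/mL (a limit of the assay, not a number)
- compound 2 `CN(C)CCCNc1nc2cc([N+](=O)[O-])ccc2nc1NCc1ccccc1` gives 2.74 ug/mL

Among the measured compounds shown here, compound 2 holds the only actual number, 2.74 ug/mL. Compound 3 `Cc1ccccc1CNc1nc2ccc([N+](=O)[O-])cc2nc1NCCCN(C)C` carries methyl in place of hydrogen on an aromatic carbon of compound 2, ortho to a large group, turning benzyl into 2-methylbenzyl (methyl in place of hydrogen on an aromatic carbon). For the measured compounds named here, no measured step exists to size this change. The estimated 1.1-fold lower number from compound 2 to compound 3 (0.04 log units; within the scatter) is expected to stay within the usual scatter, with no direction favoured. Compound 3 is expected at 2.5 ug/mL, with an estimated range of 1 ug/mL to 8 ug/mL.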

Compound 3, half-maximal inhibitory concentration: 27.6 ug/mL
Beside the measured number, compound 3's estimate is 11-fold (1.04 log units) below it; the measured number lies above the stated range.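

In this assay the change of benzyl to 2-methylbenzyl brings a 10-fold higher number from compound 2 to compound 3 (1.00 log units; beyond the scatter) and gives the series its first measured step. This position is therefore not indifferent to substitution: a single added methyl on the aromatic ring moves the read-out beyond the scatter. Nothing shown accounts for the size of this step.

Still open, going by these compounds, is whether a larger alkyl group such as ethyl, or a halogen such as chlorine, at the same place moves the number as methyl does. Also open, on these data alone, is whether the step depends on the dimethylaminopropyl chain.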